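The compounds below may be only part of what the source reports. "The series", "measured", "known", "first", "only" and "open" are said of these compounds alone.

Four compounds share one core, an imidazole-dicarboxamide bearing a dichlorophenyl amide on one side and a variable amide on the other. Compound 1 `CC(C)CNC(=O)c1[nH]cnc1C(=O)Nc1ccc(Cl)c(Cl)c1` carries an isobutyl group on that amide nitrogen, compound 2 `C[C@H](NC(=O)c1[nH]cnc1C(=O)Nc1ccc(Cl)c(Cl)c1)c1ccccc1` a 1-phenylethyl group, and compound 3 `COC(=O)[C@@H](C)NC(=O)c1[nH]cnc1C(=O)Nc1ccc(Cl)c(Cl)c1` a 1-(methoxycarbonyl)ethyl group. In a functional assay on HL-60 cells (Homo sapiens), with a stated time of 4 days (on this read-out lower numbers stand for stronger inhibition and higher numbers for weaker inhibition), compound 1 gives 7200 nM and compound 2 gives 5900 nM, a difference of a 1.2-fold lower number from compound 1 to compound 2 (0.09 log units; within the scatter). Going by these compounds, compound 3 gives only a limit in this assay, > 62500 nM, so its true number is unknown; it sits at the limit of > 62500 nM in this assay, at which 1 of the 3 values shown sits. The steps to it were an at least 8.6-fold higher number from compound 1 to compound 3 (0.93 log units; beyond the scatter) and an at least 10-fold higher number from compound 2 to compound 3 (1.02 log units; beyond the scatter), so compound 3 stands as the weakest of the three.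

Compound 4 `CCCN(CCC)C(=O)c1[nH]cnc1C(=O)Nc1ccc(Cl)c(Cl)c1` is not yet measured. It differs from compound 3 by dipropylamino in place of (1-(methoxycarbonyl)ethyl)amino on a carbonyl carbon. The two measured steps that bear on this change, from compound 1 to compound 3 and from compound 2 to compound 3, both show that swapping a plain alkyl or aryl-alkyl group for the ester-bearing group costs much activity. Reversing that, by putting a simple dipropylamino group in, is therefore expected to bring the number back down by about an at least 4.1-fold lower number from compound 3 to compound 4 (0.61 log units; beyond the scatter). For compound 4 the estimated value in this assay is 15000 nM, expected to lie between 4000 nM and 62500 nM.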

Compound 4, half-maximal inhibitory concentration: 38900 nM
Estimate against measurement, compound 4: 2.6-fold (0.41 log units) below; the measured number falls inside the stated range.
By their numbers in this assay, from the lowest: compounds 2 and 1 (each within the scatter of the next); then compound 4. At a limit, above all of these: compound 3.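

Compound 4 shows that removing the ester-bearing group does not by itself restore the activity seen with the simpler amides in this assay: dipropylamino, with its 0 hydrogen-bond donors on this carbonyl carbon, gives a 5.4-fold higher number from compound 1 to compound 4 (0.73 log units; beyond the scatter) and a 6.6-fold higher number from compound 2 to compound 4 (0.82 log units; beyond the scatter). Measured against the ester-bearing group, the same change gives an at least 1.6-fold lower number from compound 3 to compound 4 (0.20 log units; that floor lies within the scatter), so only a minimum for the gain is known, and that minimum does not clear the usual scatter. Compound 3 itself remains only a limit, so the true size of this step cannot be read: the limit of > 62500 nM in this assay, at which 1 of the 4 values shown sits.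

The compounds shown cannot separate the effect of losing the hydrogen on the amide nitrogen from the effect of carrying two propyl chains there, since compound 4 differs from compound 1 and compound 2 in both respects; a single propylamino group at this place would pull the two apart. Going by these compounds, it also remains open whether the loss with compound 3 belongs to the methyl ester itself, which a carboxylic acid or a primary amide in its place would begin to test.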